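The source may report more compounds than this note shows. Statements on the series, on what has been measured and on what is new or still open speak of the compounds shown alone.

Measured so far in an ADME assay for permeability, using PAMPA, at pH 7.4; a higher number here means that the compound crosses the layer faster, a lower number that the compound crosses the layer more slowly:
- compound 1 `Cc1cc(NC(=O)Nc2ccc(N(C)C)cc2)c2ccccc2n1`: 2 10^-6 cm/s
- compound 2 `COC(=O)c1ccc(NC(=O)Nc2cc(C)nc3ccccc23)cc1`: 448 10^-6 cm/s

Of these two compounds, compound 2 has the higher number, at 448 10^-6 cm/s, while compound 1 gives 2 10^-6 cm/s. The next compound to be measured is compound 3 `Cc1cc(NC(=O)Nc2ccc(N)cc2)c2ccccc2n1`, where amino takes the place of methoxycarbonyl on an aromatic carbon: amino in place of methoxycarbonyl on an aromatic carbon.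

Within the data shown here, only one measured step bears on this change. It is a 220-fold higher number from compound 1 to compound 2 (2.35 log units; beyond the scatter), a large step that came with methoxycarbonyl replacing dimethylamino on an aromatic carbon. The new change runs the other way, removing methoxycarbonyl, although amino rather than dimethylamino enters. A single step is a thin basis, and the data do not show how amino and dimethylamino compare in this assay. Even so, a large fall is expected, beyond the scatter but perhaps not quite as large as the measured step: a 110-fold lower number from compound 2 to compound 3 (2.05 log units; beyond the scatter). The estimate for compound 3 is 4 10^-6 cm/s, with an expected range from 0.7 10^-6 cm/s to 40 10^-6 cm/s.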

Compound 3, apparent permeability: 530 10^-6 cm/s
For compound 3 the middle estimate is 130-fold (2.12 log units) below the measured one; measured number outside the range, above it.
By their numbers in this assay, from the lowest: compound 1; then compounds 2 and 3 (each within the scatter of the next).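

In this assay, amino in place of methoxycarbonyl on this aromatic carbon gives a 1.2-fold higher number from compound 2 to compound 3 (0.07 log units; within the scatter), so the two groups cannot be told apart here, even though amino has fewer heavy atoms and, unlike methoxycarbonyl, carries a hydrogen-bond donor. The earlier step could be read as the loss of methoxycarbonyl lowering the number, but compound 3 has no methoxycarbonyl and does not share the low number of compound 1. Amino in place of dimethylamino instead gives a 270-fold higher number from compound 1 to compound 3 (2.42 log units; beyond the scatter), which places the large difference on dimethylamino among these three groups, though nothing measured here explains why dimethylamino stands apart.

Among these compounds, with only three groups at this position, it remains open whether the low number belongs to dimethylamino alone or extends to other substituted amines, such as methylamino or diethylamino. A carboxylic acid or a hydroxyl group on the same carbon would show how far the range shared by amino and methoxycarbonyl reaches.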